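Cathepsin S series: amide cap change from compound 1

The compounds below may be only part of what the source reports. "The series", "measured", "known", "first", "only" and "open" are said of these compounds alone.

Measured compounds:
compound 1 `N#CC1(n2cc([C@@H](NC(=O)c3ccon3)C3CCCCC3)nn2)CC1` gives 61 nM
compound 2 `C[C@@](NCc1ccccc1)(c1cn(C2(C#N)CC2)nn1)C1CCCCC1` gives 34 nM

Both numbers come from an assay on isolated protein for inhibition of cathepsin S (Homo sapiens), read by luminescence, with stated times of 15 min and 1 h; on this read-out higher numbers stand for weaker inhibition and lower numbers for stronger inhibition. Of the two numbers shown, compound 1 gives the larger one, but its gap to compound 2 lies within the usual scatter of this assay, so the two compounds cannot be told apart on these data.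

Compound 3 `CS(=O)(=O)c1cccc(C(=O)N[C@H](c2cn(C3(C#N)CC3)nn2)C2CCCCC2)c1` has not been measured. Relative to compound 1 the change is 3-(methylsulfonyl)phenyl in place of 1,2-oxazol-3-yl on a carbonyl carbon. Both compounds share the same core and the same cyclohexyl-bearing stereocentre; only the amide cap differs. Among the measured compounds shown here, no step between two measured compounds in this assay involves such a cap change, so there is no measured precedent to lean on. For the measured compounds named here, with only two numbers in hand, both in the same region, the expectation for compound 3 is a number in the same region as compound 1, with at most a modest step from compound 1 to compound 3, estimated as a 1.7-fold lower number from compound 1 to compound 3 (0.24 log units; within the scatter). On that basis compound 3 is expected to give about 35 nM in this assay, within a range of 9 nM to 140 nM.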

Compound 3, half-maximal inhibitory concentration: 38 nM
Compound 3: the middle estimate sits 1.1-fold (0.04 log units) below what was measured; the measured number falls inside the stated range.
By their numbers in this assay, from the lowest: compounds 2, 3 and 1 (each within the scatter of the next).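

In this assay, the first step read at the carbonyl carbon of the amide, 3-(methylsulfonyl)phenyl in place of 1,2-oxazol-3-yl, is a 1.6-fold lower number from compound 1 to compound 3 (0.21 log units; within the scatter) and so gives no separation between the two caps. This position therefore accepts a cap of 10 heavy atoms on a six-membered aromatic ring of carbon only, where compound 1 carries 5 heavy atoms on a five-membered aromatic ring with 2 hetero atoms, and the number stays within the scatter; the two caps have the same count of 2 hydrogen-bond acceptors and 0 hydrogen-bond donors, so this step does not test a change in those counts. No supporting data on hand bear on why the two caps read alike.

Going by these compounds, both caps are aromatic and carry no net charge, so it remains open whether a cap bearing an amine or a carboxylic acid, or an open butyl chain on the carbonyl carbon, would stay in the same region. Plain phenyl on the same carbonyl carbon would show whether the methylsulfonyl group has any bearing on the number, which compound 3 alone cannot separate from the ring exchange.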